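Swapping an aromatic amine for a flexible amino chain

The source may report more compounds than this note shows. Statements on the series, on what has been measured and on what is new or still open speak of the compounds shown alone.

Measured compounds:
- Compound 1 `Nc1ccc(Nc2c(C(=O)NCc3ccc(F)cc3)nc(Br)c3cccnc23)cc1`: 10000 nM
- Compound 2 `C[C@H](CO)Nc1nc(C(=O)NCc2ccc(F)cc2)c(O)c2ncccc12`: "not determined" (no result reported)
- Compound 3 `O=CNCCCCCCNc1nc(C(=O)NCc2ccc(F)cc2)c(O)c2ncccc12`: 4000 nM

The compounds were tested in a functional assay on HCT-116 cells (Homo sapiens) for cytotoxicity, read by MTT assay, with a stated time of 72 h; a higher number here means a weaker inhibitor, a lower number a stronger inhibitor. Compound 1 gives 10000 nM, the highest number among the two compounds that returned a figure; compound 3 gives 4000 nM, a lower number and a gap that lies beyond the usual scatter. Compound 2 returned no result.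

Compound 4 `NCCCCCCNc1c(C(=O)NCc2ccc(F)cc2)nc(Br)c2cccnc12` keeps the core of compound 1 and changes one group:

6-aminohexyl in place of 4-aminophenyl on a nitrogen on an aromatic ring

Among the measured compounds shown here, no pair of compounds that differ in a single place has been measured, so the size of this step has no direct precedent. Compound 3 carries an amine-bearing chain and sits lower than compound 1, but it differs in more than one place, so it offers only a hint. A modest shift toward a lower number is expected from compound 1 to compound 4, a 2.0-fold lower number from compound 1 to compound 4 (0.30 log units; within the scatter), with a wide range. Compound 4 is therefore estimated at 5000 nM, between 1500 nM and 15000 nM.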

Compound 4, half-maximal inhibitory concentration: 7000 nM
Beside the measured number, compound 4's estimate is 1.4-fold (0.15 log units) below it; low and high end bracket the measured number.
By their numbers in this assay, from the lowest: compounds 3, 4 and 1 (each within the scatter of the next, the first and the last beyond it).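

In this assay, among the compounds shown here, putting 6-aminohexyl in place of 4-aminophenyl on a nitrogen on an aromatic ring gives a 1.4-fold lower number from compound 1 to compound 4 (0.15 log units; within the scatter), the first comparison here that isolates a single place. The six-membered aromatic ring of carbon gives way to a chain with no ring, while the counts of heavy atoms, hydrogen-bond donors and hydrogen-bond acceptors stay the same, and this exchange leaves the two compounds indistinguishable in this assay. No measurement at hand explains why the two groups read alike.

As far as these compounds go, whether a shorter chain, a longer chain or a carboxylic acid at the end of the chain would move the number beyond the scatter remains open. So does whether the same exchange would read alike on a different core, such as the one carried by compound 3.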